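A few compounds are considered here, and "the series" means these few. Any claim that something is new, unique, unknown or untested is made for them only; others in the source may bear on it.

Measured compounds:
compound 1 `COc1cccc(Cc2ccnn(CC(=O)Nc3ccc(Br)cc3)c2=O)c1`, in an assay on HL-60 cells for agonist activity at N-formyl peptide receptor 3 (Homo sapiens), read by calcium flux (a lower number here means that less compound is needed, a higher number that more compound is needed for the effect), compound 1 gives 14600 nM
compound 2 `COc1ccc(Cc2cc(-c3cccs3)nn(CC(=O)Nc3ccc(Br)cc3)c2=O)cc1`, in this assay compound 2 gives only a limit, > 50000 nM

Compound 2 thus stands at the limit of > 50000 nM in this assay, at which 1 of the 2 values shown sits, so no number is known for it. Compound 3 `COc1ccc(Cc2cc(-c3ccc(Cl)cc3)nn(CC(=O)Nc3ccc(Br)cc3)c2=O)cc1` is not yet measured; it differs from compound 2 by 4-chlorophenyl in place of thiophen-2-yl on an aromatic carbon. Among the measured compounds shown here, no step between measured compounds covers this change, and the value of compound 2 is a limit, so the expected step is unclear; the exchange is expected to move potency little beyond the scatter, if at all, with compound 3 likely remaining near the limit as a step that the limit leaves unreadable from compound 2 to compound 3. Compound 3 is estimated at 60000 nM, within 20000 nM to 200000 nM.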

Compound 3, half-maximal effective concentration: > 50000 nM
Compound 3: only a limit was reported; the forecaster's own chance of this, stated with the estimate: 70%; the middle value lies beyond the limit too.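

Compound 2 and compound 3 each give only a limit, not a number, so no step can be read between them: the limit of > 50000 nM in this assay, at which 2 of the 3 values shown sit.

The compounds shown leave open whether thiophen-2-yl and 4-chlorophenyl differ at all in this assay.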